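Swapping the Amine on the Sulfonyl: Metabolic Stability

The source may report more compounds than this note shows. Statements on the series, on what has been measured and on what is new or still open speak of the compounds shown alone.

Measured compounds:
Compound 1 `O=C([C@@H]1CCCN(S(=O)(=O)c2ccc(S(=O)(=O)N3CC[C@@H](O)C3)cc2)C1)N1CCC(F)(F)CC1` gives 0.517 h in an ADME assay on microsomes from liver (Homo sapiens) for metabolic stability, read by LC-MS, using NADPH, with a stated time of 60 min, tested at 10 uM; a higher number here means that the compound lasts longer, a lower number that the compound disappears faster.
Compound 2 `CCN(CC)S(=O)(=O)c1ccc(S(=O)(=O)N2CCC[C@@H](C(=O)N3CCC(F)(F)CC3)C2)cc1` gives 0.0457 h in this assay.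

Compound 1 stands highest of the two numbers in this assay. Compound 3 `CC(C)NS(=O)(=O)c1ccc(S(=O)(=O)N2CCC[C@@H](C(=O)N3CCC(F)(F)CC3)C2)cc1` differs from it as follows: isopropylamino in place of 3-hydroxypyrrolidin-1-yl on a sulfonyl sulfur. For the measured compounds named here, the one measured step that bears on this change is an 11-fold lower number from compound 1 to compound 2 (1.05 log units; beyond the scatter), also a swap of the same ring for an acyclic amine on the same sulfonyl sulfur. A drop beyond the scatter is therefore expected for compound 3, though the step of a 4.3-fold lower number from compound 1 to compound 3 (0.63 log units; beyond the scatter) is estimated somewhat smaller. Compound 3 is expected to give about 0.12 h, within 0.04 h to 0.35 h.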

Compound 3, half-life: 0.328 h
Estimate against measurement, compound 3: 2.7-fold (0.44 log units) below; measured number inside the range.
By their numbers in this assay, from the lowest: compound 2; then compounds 3 and 1 (each within the scatter of the next).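

In this assay, a 1.6-fold lower number from compound 1 to compound 3 (0.20 log units; within the scatter) stays within the scatter, so among these compounds neither the ring nor the oxygen of 3-hydroxypyrrolidin-1-yl is needed to reach this level. By contrast, a 7.2-fold higher number from compound 2 to compound 3 (0.86 log units; beyond the scatter) lies beyond the scatter, so the earlier drop does not extend to every acyclic amine on this sulfonyl sulfur: compound 2 falls away, while compound 3 does not.

Nothing measured here explains why these two acyclic amines differ. Also open, as far as these compounds go, is whether a morpholine or an unsubstituted pyrrolidine on the same sulfur would track compound 1 or compound 2.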